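Aryl amide swap on the piperazine-bearing core

The source may report more compounds than this note shows. Statements on the series, on what has been measured and on what is new or still open speak of the compounds shown alone.

Three compounds of this series have numbers in a functional assay on SK-BR-3 cells (Homo sapiens) for antiproliferative activity, read by MTT assay, with a stated time of 72 h; a higher number here means a weaker inhibitor, a lower number a stronger inhibitor. Compound 1 `CNc1cc(C)c2cc(NC(=O)c3ccc(Cl)c(Cl)c3)ccc2n1` gives 6350 nM. Among the compounds with values here, compound 2 `CCNc1cc(C)c2cc(NC(=O)c3ccc(Cl)c(Cl)c3)ccc2n1` gives 28200 nM, and the only measured step, a 4.4-fold higher number from compound 1 to compound 2 (0.65 log units; beyond the scatter), concerns the amine side of the core, not the aryl amide. Compound 3 `CCN1CCN(c2cc(C)c3cc(NC(=O)c4ccccc4F)ccc3n2)CC1` gives 38100 nM, the highest of the three numbers; its gap to compound 2 lies within the scatter, while its gap to compound 1 lies beyond it. Within the data shown here, compound 3 also differs from the other two in the amine on the core and in the aryl amide at once, so no single measured step isolates either change.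

Compound 4 `CCc1ccc(C(=O)Nc2ccc3nc(N4CCN(CC)CC4)cc(C)c3c2)cc1` is to be measured in this assay. It differs from compound 3 by 4-ethylphenyl in place of 2-fluorophenyl on a carbonyl carbon. Among the measured compounds shown here, no measured step touches the aryl group on the carbonyl carbon, so nothing in the data points to a direction for this change. The expectation is therefore a step of a 1.3-fold lower number from compound 3 to compound 4 (0.10 log units; within the scatter), which is not beyond the scatter. For compound 4 the estimate in this assay is 30000 nM, with a range from 8000 nM to 100000 nM, and a real chance that only a limit is reported.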

Compound 4, half-maximal inhibitory concentration: 9850 nM
Compound 4: the middle estimate sits 3.0-fold (0.48 log units) above what was measured; the measured number falls inside the stated range.
By their numbers in this assay, from the lowest: compounds 1 and 4 (each within the scatter of the next); then compounds 2 and 3 (each within the scatter of the next).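

Within the data shown here, the aryl group on the carbonyl carbon is not a silent position in this assay: 4-ethylphenyl in place of 2-fluorophenyl gives a 3.9-fold lower number from compound 3 to compound 4 (0.59 log units; beyond the scatter), the first reading of a change at this place with the rest of the structure held constant. This position therefore joins the amine side of the shared core, where a 4.4-fold higher number from compound 1 to compound 2 (0.65 log units; beyond the scatter) was already on record, as a second place where one change moves the number beyond the scatter. No accompanying measurement bears on why the number moves here.

The step replaces one substituted phenyl with another, so the loss of the fluorine and the arrival of the ethyl group cannot be told apart, and an unsubstituted phenyl, a methoxy group or a longer chain in place of the ethyl group would be needed to begin separating them. Among these compounds, whether the same aryl change would carry over to the amines of compound 1 and compound 2 also remains open, as the piperazine-bearing compounds 3 and 4 are the only pair that reads it.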